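The source may report more compounds than this note shows. Statements on the series, on what has been measured and on what is new or still open speak of the compounds shown alone.

Measured so far:
Compound 1, `CCSCCC12CCC(c3nnc(-c4ccccc4C(F)(F)F)n3C)(CC1)CC2`, in an assay on CHO-K1 cells for inhibition of 11-beta-hydroxysteroid dehydrogenase type 2 (Homo sapiens), read by scintillation proximity assay (on this read-out higher numbers stand for weaker inhibition and lower numbers for stronger inhibition), gives > 4000 nM; this is a limit of the assay, not a number.
Compound 2, `CCCCCC12CCC(c3nnc(-c4ccccc4C(F)(F)F)n3C)(CC1)CC2`, in this assay gives 1300 nM.

For the measured compounds named here, compound 2 thus holds the only real number in this assay; the other entry is a limit. The unmeasured compound 3, `CC(F)CCCC12CCC(c3nnc(-c4ccccc4C(F)(F)F)n3C)(CC1)CC2`, differs from compound 2 in one place: fluoro in place of hydrogen on a saturated chain carbon bound to two saturated chain carbons. Going by the values given here, the single measured step, an at least 3.0-fold lower number from compound 1 to compound 2 (0.48 log units; beyond the scatter), changed the end of the same side chain by replacing ethylsulfanyl with propyl; its size is known only as a bound because the limit of > 4000 nM in this assay, at which 1 of the 2 values shown sits, caps what compound 1 can show. That step concerns a different kind of change, a swap of one terminal group for another, rather than the insertion of a fluorine into the chain, so it gives no direct guide to the present change. With nothing pointing in either direction, no step beyond the scatter is expected in this assay. Compound 3 is therefore estimated at about 1500 nM, likely between 500 nM and 4500 nM. This corresponds to an expected 1.2-fold higher number from compound 2 to compound 3 (0.06 log units; within the scatter).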

Compound 3, half-maximal inhibitory concentration: 1300 nM
Estimate against measurement, compound 3: 1.2-fold (0.06 log units) above; the measured number falls inside the stated range.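

In this assay, fluoro in place of hydrogen on a saturated chain carbon bound to two saturated chain carbons gives no change at the digits printed from compound 2 to compound 3 (within the scatter), so at this one chain position the fluoro swap leaves the read-out within the usual scatter of repeated measurements. The difference from the ethylsulfanyl chain also remains once the fluoro is present, with an at least 3.0-fold lower number from compound 1 to compound 3 (0.48 log units; beyond the scatter). The size of that step is known only as a bound, since compound 1 gives a limit of the assay and not a number: the limit of > 4000 nM in this assay, at which 1 of the 3 values shown sits.

What the compounds shown leave open is whether this result is particular to this carbon or holds along the chain, since fluoro appears at just one position here. They also leave open how a hydroxyl group or an amine on the same carbon, or a longer chain in place of the 3-fluorobutyl end, would read in this assay, so the tolerance seen for fluoro cannot be extended to other groups.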